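Methoxy added to the aryl ring of compound 2

The source may hold more compounds than are shown below. What is called first, only, known or untested is meant among the compounds shown, and "the series" means these compounds.

Measured so far:
compound 1 `CCn1c(SCC(=O)Nc2ccc(/C(C)=N/O)cc2)nnc1-c1cc(OC)c(OC)c(OC)c1`, 29%
compound 2 `CCn1c(SCC(=O)Nc2ccc(C(C)=O)cc2)nnc1-c1ccc(OC)c(OC)c1`, 56%
compound 3 `C=CCn1c(SCC(=O)Nc2ccc(C(C)=O)cc2)nnc1-c1ccc(OC)c(OC)c1`, 56%

All three were read in a functional assay on the whole organism (strain albino) for inhibition, with Rattus norvegicus as the target, read by paw edema, with stated times of 30 min and 1 h, at a dose of 0.28 mmol/kg by the oral route; on this read-out higher numbers stand for more inhibition at the one dose given (going by the name of the read-out) and lower numbers for less inhibition. Compound 2 gives 56%, level with compound 3 at the digits shown and, together with compound 3, the highest of the three numbers; compound 1 lies furthest away, its number being lower by an amount beyond the scatter.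

Compound 4 `CCn1c(SCC(=O)Nc2ccc(C(C)=O)cc2)nnc1-c1cc(OC)c(OC)c(OC)c1` is the next compound to be read. Relative to compound 2 it differs as follows: methoxy in place of hydrogen on an aromatic carbon.

For the measured compounds named here, the one step measured so far, no change at the digits printed from compound 2 to compound 3 (within the scatter), concerns a different site and does not bear on this change. Compound 1 carries the methoxy group that enters in compound 4, yet differs from compound 4 in a second place as well; the value of compound 1, 29%, is therefore only a loose pointer. A modest drop from compound 2 is expected, a number 11 percentage points lower from compound 2 to compound 4 (beyond the scatter), with wide uncertainty. Compound 4 is thus estimated at 45%, within 25% to 62%.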

Compound 4, a percentage reported as inhibition, in the whole organism at one dose (the size of the read-out at that dose, not a potency): 46%
The estimate for compound 4 lay 1 percentage points below the measured number; the range from low to high includes it.
By their numbers in this assay, from the lowest: compound 1; then compounds 4, 2 and 3 (each within the scatter of the next).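

In this assay, the methoxy group entering on the aromatic carbon ortho to a methoxy group and meta to a large group gives a number 10 percentage points lower from compound 2 to compound 4 (within the scatter), so this change on the aryl ring does not separate the two compounds beyond the usual scatter. With that methoxy present in both compounds, replacing the group of 4 heavy atoms with the group of 3 heavy atoms on the other aromatic carbon gives a number 17 percentage points higher from compound 1 to compound 4 (beyond the scatter), which places the clearer difference at that second site. No measurement available here gives a reason for either step.

From the compounds shown here alone, whether a hydroxy group, a chlorine or an amine at the new methoxy position would read differently remains open. Also open, going by these compounds, is whether the methoxy step would read the same on the core of compound 3.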